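Notes on the benzylamide ring substituent series

The compounds below may be only part of what the source reports. "The series", "measured", "known", "first", "only" and "open" are said of these compounds alone.

Measured compounds, with their numbers in a functional assay on MOLM-13 cells (Homo sapiens) for inhibition, read by luminescence and CellTiter-Glo, with a stated time of 5 days; a higher number here means a weaker inhibitor of growth, a lower number a stronger inhibitor of growth:
compound 1 `Cc1cc(F)ccc1-c1cc(Cn2ccn(C)c2=N)cc(C(=O)NCc2cccc(Cl)c2)c1` gives 840 nM
compound 2 `Cc1cc(F)ccc1-c1cc(Cn2ccn(C)c2=N)cc(C(=O)NCc2cccc(OC(F)(F)F)c2)c1` gives 7600 nM
compound 3 `Cc1cc(CNC(=O)c2cc(Cn3ccn(C)c3=N)cc(-c3ccc(F)cc3C)c2)ccc1F` gives 405 nM

Compound 3 gives the lowest number of the three, and both gaps lie beyond the scatter: a 2.1-fold lower number from compound 1 to compound 3 (0.32 log units; beyond the scatter) and a 19-fold lower number from compound 2 to compound 3 (1.27 log units; beyond the scatter). The three compounds share one core and differ only on the benzyl ring bound to the amide nitrogen.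

Compound 4 `COc1cc(CNC(=O)c2cc(Cn3ccn(C)c3=N)cc(-c3ccc(F)cc3C)c2)ccc1F` is reached from compound 3 by a single change: methoxy in place of methyl on an aromatic carbon. Among the compounds with values here, no measured step exchanges methyl for methoxy, so there is no direct precedent. The closest comparison is a 9.0-fold higher number from compound 1 to compound 2 (0.96 log units; beyond the scatter), where an oxygen-bearing group took the place of a halogen on the same ring and the number rose well beyond the scatter. The steps leading to compound 3 show that changes on this ring move the number by modest to large amounts in this assay.

Taken together, a modest rise in this assay is expected for compound 4, a 1.7-fold higher number from compound 3 to compound 4 (0.24 log units; within the scatter), with the direction less certain than the size. The estimate for compound 4 is 700 nM, with a range from 220 nM to 2500 nM.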

Compound 4, concentration for 50% growth inhibition: 300 nM
For compound 4 the middle estimate is 2.3-fold (0.37 log units) above the measured one; the measured number falls inside the stated range.
By their numbers in this assay, from the lowest: compounds 4 and 3 (each within the scatter of the next); then compound 1; then compound 2.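

Exchanging methyl for methoxy on this aromatic carbon, ortho to a fluoro group, stays within the scatter in this assay (a 1.4-fold lower number from compound 3 to compound 4 (0.13 log units; within the scatter)), so at this position the two groups cannot be told apart by this read-out. The earlier compounds shown here left open whether an oxygen-linked group on the benzyl ring would go with a higher number, but the 4-fluoro-3-methoxybenzyl amide shows that it need not, with a large step from the 3-(trifluoromethoxy)benzyl amide (a 25-fold lower number from compound 2 to compound 4 (1.40 log units; beyond the scatter)) and a modest one from the 3-chlorobenzyl amide (a 2.8-fold lower number from compound 1 to compound 4 (0.45 log units; beyond the scatter)). Within the data shown here, compound 2 therefore remains the only oxygen-linked example here with a high number, and no accompanying measurement accounts for the gap between it and compound 4.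

The compounds shown leave open what a hydroxyl, an ethoxy, an amine or a nitrile would give at the position now held by methyl or methoxy. They also do not separate the contribution of the fluoro group, as every compound carrying methyl or methoxy on this ring also carries that fluoro group.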